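The source may report more compounds than this note shows. Statements on the series, on what has been measured and on what is new or still open speak of the compounds shown alone.

- compound 1 `CCn1c(C(=O)NCCCN(C)C)ccc1C(CC)(CC)c1ccc(OCCC(O)(CC)CC)c(C)c1`: 3350 nM
- compound 2 `C=CCN(C)C(=O)c1ccc(C(CC)(CC)c2ccc(OCCC(O)(CC)CC)c(C)c2)n1CC`: > 50000 nM

Both compounds were tested in a functional assay on MCF7 cells (Homo sapiens) for antiproliferative activity, read by MTT assay, with a stated time of 48 h; a lower number here means a stronger inhibitor, a higher number a weaker inhibitor. The value of compound 2, > 50000 nM, is a limit and not a number. Compound 2 therefore stands at the limit of > 50000 nM in this assay, at which 1 of the 2 values shown sits.

Compound 3 `CCOc1ccc(NC(=O)c2ccc(C(CC)(CC)c3ccc(OCCC(O)(CC)CC)c(C)c3)n2CC)cc1` keeps the shared core and differs from compound 2 at one place: (4-ethoxyphenyl)amino in place of allyl(methyl)amino on a carbonyl carbon. In words, (4-ethoxyphenyl)amino stands in place of allyl(methyl)amino on a carbonyl carbon.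

Among the measured compounds shown here, the one measured step that bears on this change lies at the same place: an at least 14-fold higher number from compound 1 to compound 2 (1.17 log units; beyond the scatter). It shows that the group on this carbonyl carbon can move the number by a large amount, but it involves neither the group entering here nor any measured aryl amide. With a limit as the starting point, the size of the next step is poorly fixed, and compound 3 may also reach the limit. A modest move towards a lower number is the tentative expectation. The expected change is an at least 2.5-fold lower number from compound 2 to compound 3 (0.39 log units; beyond the scatter). For compound 3 the estimated value is 20000 nM, with an expected range from 4000 nM to 50000 nM.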

Compound 3, half-maximal inhibitory concentration: > 50000 nM
Compound 3 gave a limit, no number; the forecaster's own chance of this, stated with the estimate: 45%; at least 2.5-fold (0.39 log units) between middle value and limit.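

In this assay compound 3 gives > 50000 nM, which is a limit and not a number, and the step from compound 2, itself a limit, cannot be read. Against compound 1 the change can be read, as an at least 14-fold higher number from compound 1 to compound 3 (1.17 log units; beyond the scatter), with 4-ethoxyphenyl in place of 3-(dimethylamino)propyl on an amide-type nitrogen. Two very different groups on this carbonyl carbon, allyl(methyl)amino and (4-ethoxyphenyl)amino, thus end at the same limit, and of the compounds shown only compound 1 gives a readable number: the limit of > 50000 nM in this assay, at which 2 of the 3 values shown sit.

From the compounds shown here alone, what remains open is whether the number of compound 1 depends on the dimethylamino group at the end of its chain or on the propyl chain that carries it. A plain propyl chain or a 3-hydroxypropyl chain on the amide nitrogen would separate these two parts, and a 2-(dimethylamino)ethyl chain would show how much the length of the chain matters.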